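The source may hold more compounds than are shown below. What is called first, only, known or untested is meant among the compounds shown, and "the series" means these compounds.

Measured so far in a functional assay on MCF7 cells (Homo sapiens) for cytotoxicity, read by sulforhodamine B assay; on this read-out higher numbers stand for weaker inhibition of growth and lower numbers for stronger inhibition of growth
compound 1 `COc1ccc(/C=N\NC(=S)NC(C)(C)CCC[C@](C)(O)[C@@H]2CC=C(C)CC2)cc1` gives 6500 nM
compound 2 `CC1=CC[C@@H]([C@@](C)(O)CCCC(C)(C)NC(=S)N/N=C\c2ccc(N(C)C)cc2)CC1` gives 14000 nM
compound 3 `CC1=CC[C@@H]([C@@](C)(O)CCCC(C)(C)NC(=S)N/N=C\c2ccc([N+](=O)[O-])cc2)CC1` gives 17700 nM

The position of compound 3 rests on two steps (a 2.7-fold higher number from compound 1 to compound 3 (0.44 log units; beyond the scatter)) and (a 1.3-fold higher number from compound 2 to compound 3 (0.10 log units; within the scatter)). The values of compound 2 and compound 3 cannot be told apart, and only compound 1 stands clear of them, on the side of stronger inhibition of growth.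

Compound 4 `CC1=CC[C@@H]([C@@](C)(O)CCCC(C)(C)NC(=S)N/N=C\c2ccc(Cl)cc2)CC1` keeps the shared core and carries chloro in place of nitro on an aromatic carbon, para to a large group (chloro in place of nitro on an aromatic carbon). Among the compounds with values here, no chloro analogue has been measured, so the only guide is the swaps already made at this same aromatic carbon. The two steps away from methoxy are modest (a 2.2-fold higher number from compound 1 to compound 2 (0.33 log units; beyond the scatter)) and (a 2.7-fold higher number from compound 1 to compound 3 (0.44 log units; beyond the scatter)), and the swap between dimethylamino and nitro stays within the scatter. Across these groups the numbers in this assay have moved little, and a similarly small step is expected here. A slight move toward a lower number is expected, not beyond the scatter (a 1.6-fold lower number from compound 3 to compound 4 (0.21 log units; within the scatter)). The estimate for compound 4 is 11000 nM (expected range 5500 nM to 22000 nM).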

Compound 4, concentration for 50% growth inhibition: 6890 nM
The estimate for compound 4 lay 1.6-fold (0.20 log units) above the measured number; measured number inside the range.
By their numbers in this assay, from the lowest: compounds 1 and 4 (each within the scatter of the next); then compounds 2 and 3 (each within the scatter of the next).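

In this assay, exchanging nitro for chloro at this aromatic carbon gives a change beyond the scatter, a 2.6-fold lower number from compound 3 to compound 4 (0.41 log units; beyond the scatter), where the earlier exchange between nitro and dimethylamino did not, and the exchange of dimethylamino for chloro also clears it, a 2.0-fold lower number from compound 2 to compound 4 (0.31 log units; beyond the scatter). Chloro cannot be told apart from methoxy, a 1.1-fold higher number from compound 1 to compound 4 (0.03 log units; within the scatter), so the side of stronger inhibition of growth no longer rests on compound 1 alone: the four compounds now form two pairs, compound 1 with compound 4 and compound 2 with compound 3. No measurement at hand bears on what separates these two pairs.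

The compounds shown leave open whether this two-pair split holds for other groups on the same aromatic carbon, such as fluoro, bromo, trifluoromethyl, a nitrile or a carboxylic acid, and how an unsubstituted phenyl ring compares with all of them. They also leave open whether the steps seen here would keep their size if the hydroxyl group on the shared core were replaced by a methyl ether or a ketone.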